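The compounds below may be only part of what the source reports. "The series", "measured", "known", "first", "only" and "open" are said of these compounds alone.

Compound 2 `O=Cc1ccc(-c2cn3ccnc3c(-c3ccc4ncn(C5CCCCC5)c4c3)n2)cc1` stands highest of the two numbers in a functional assay on UACC-62 cells (Homo sapiens) for inhibition, read by sulforhodamine B assay, with a stated time of 48 h, tested at 10 uM (on this read-out lower numbers stand for less inhibition and higher numbers for more inhibition at the one concentration tested (going by the name of the read-out)), where compound 2 gives 37.1%. Going by the values given here, its nearest neighbour is compound 1 `Brc1cn2ccnc2c(-c2ccc3ncn(C4CCCCC4)c3c2)n1`, which in this assay gives 19.8%; the step of a number 17.3 percentage points higher from compound 1 to compound 2 (beyond the scatter) lies beyond the scatter and is the only measured step so far. Compound 3 `c1ccc2c(-c3cn4ccnc4c(-c4ccc5ncn(C6CCCCC6)c5c4)n3)cccc2c1` has not yet been measured. It differs from compound 2 by naphthalen-1-yl in place of 4-formylphenyl on an aromatic carbon. Among the compounds with values here, no measured step covers this exchange of one ring group for another at the same place. Within the data shown here, the one step that bears on it at all, a number 17.3 percentage points higher from compound 1 to compound 2 (beyond the scatter), shows that a six-membered aromatic ring of carbon only in place of bromo raised inhibition in this assay; compound 3 keeps an aromatic ring at that place, so the gain seen in compound 2 is expected to be largely kept, while the loss of the hydrogen-bond acceptor of the 4-formylphenyl leaves the direction of any further shift open. For compound 3 the expected step is a number 2.1 percentage points lower from compound 2 to compound 3 (within the scatter), within the scatter. The estimate for compound 3 in this assay is 35%, ranging from 15% to 55%.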

Compound 3, a percentage reported as inhibition, at one concentration (the size of the read-out at that concentration, not a potency): 16.7%
Compound 3: the middle estimate sits 18.3 percentage points above what was measured; measured number inside the range.
By their numbers in this assay, from the lowest: compounds 3 and 1 (each within the scatter of the next); then compound 2.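

In this assay, the result shows that an aromatic ring on this carbon does not by itself carry the gain seen with 4-formylphenyl: naphthalen-1-yl in place of 4-formylphenyl gives a number 20.4 percentage points lower from compound 2 to compound 3 (beyond the scatter), a step beyond the scatter. Naphthalen-1-yl in place of bromo gives a number 3.1 percentage points lower from compound 1 to compound 3 (within the scatter), so at this place the fused pair of aromatic rings cannot be told apart from the bromo group, despite the much larger group. Of the three groups shown, only 4-formylphenyl stands apart, with its steps to both of the others beyond the scatter, which makes this position sensitive to the kind of ring group it carries and not merely to the presence of one.

As far as these compounds go, the exchange changes the ring count, the size of the group and the presence of a hydrogen-bond acceptor all at once, so it remains open whether a plain phenyl, or a phenyl carrying a carboxylic acid or an amine in place of the aldehyde, would stand with compound 2 or with compound 1 and compound 3. Nothing at hand explains why these groups differ in this assay.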